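Swapping a halogen on an aromatic ring

The source may hold more compounds than are shown below. What is called first, only, known or untested is meant among the compounds shown, and "the series" means these compounds.

Of the compounds shown here, two have been tested in a functional assay on the whole organism (strain Wistar) for inhibition, with Rattus norvegicus as the target, read by paw edema, with a stated time of 3 h, at a dose of 10 mg/kg by the oral route; on this read-out higher numbers stand for more inhibition at the one dose given (going by the name of the read-out) and lower numbers for less inhibition. Compound 1, with the structure `COc1ccc2cc(C(C)c3nnc(COc4ccc(-c5ccccc5)cc4)o3)ccc2c1`, gives 25% in this assay. Compound 2, with the structure `Sc1nnc(COc2ccc(-c3ccccc3)cc2)n1-c1ccc(Cl)cc1`, gives 15.9% in this assay. The two numbers lie within the usual scatter of each other, so compound 2 stands alongside compound 1 with no real separation between them; neither number can be called higher or lower on this evidence.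

Compound 3, with the structure `Fc1ccc(-n2c(S)nnc2COc2ccc(-c3ccccc3)cc2)cc1`, has not yet been measured. It differs from compound 2 in one place: fluoro in place of chloro on an aromatic carbon. The difference is a single halogen atom on the six-membered aromatic ring of carbon only, para to a large group, so that a 4-chlorophenyl becomes a 4-fluorophenyl. For the measured compounds named here, no pair of measured compounds shows what such a swap does here.

Going by the values given here, with only two measured compounds, both within scatter of each other, the expectation is a step from compound 2 to compound 3 of a number 1.1 percentage points higher from compound 2 to compound 3 (within the scatter), that is, none beyond the scatter. Compound 3 is therefore estimated at 17% in this assay, with a range from 5% to 30%.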

Compound 3, a percentage reported as inhibition, in the whole organism at one dose (the size of the read-out at that dose, not a potency): 75%
Beside the measured number, compound 3's estimate is 58 percentage points below it; measured number above the stated range.
By their numbers in this assay, from the lowest: compounds 2 and 1 (each within the scatter of the next); then compound 3.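

Turning the 4-chlorophenyl into a 4-fluorophenyl gives, in this assay, a number 59.1 percentage points higher from compound 2 to compound 3 (beyond the scatter). So this aromatic carbon, para to a large group, is not a place where one halogen can stand in for another without consequence, even though compound 2 and compound 3 differ by just that one atom. The leaving and entering groups look alike in every count available here, each being a single heavy atom with no ring, no hydrogen-bond donors or acceptors and no net charge, and no measurement shown bears on why the swap has so large an effect.

The compounds shown leave open what else this carbon would accept: a bromo, a methoxy group or an amine could each land near compound 2, near compound 3 or somewhere else entirely. Also open, on these data alone, is whether fluoro in this place would matter as much on another core or at other doses, since compound 1 differs from the others in more than one place and each compound has a reading at a single dose.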